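Phenyl to 4-fluorophenyl: expectation for compound 4

The source may hold more compounds than are shown below. What is called first, only, known or untested is meant among the compounds shown, and "the series" means these compounds.

Going by the values given here, compound 1 `COc1ccc(Nc2nc3ccccc3nc2S(=O)(=O)c2ccccc2)cc1` gives 1510 nM in a functional assay on PC-3 cells (Homo sapiens) for cytotoxicity, read by MTT assay, with a stated time of 72 h (on this read-out lower numbers stand for stronger inhibition and higher numbers for weaker inhibition), the lowest of the three numbers measured so far. Compound 3 `O=S(=O)(c1ccccc1)c1nc2ccccc2nc1Nc1ccc(C(F)(F)F)cc1` gives 3550 nM in this assay, and compound 2 `O=S(=O)(c1ccccc1)c1nc2ccccc2nc1Nc1ccc(Cl)cc1` gives 15300 nM in this assay. The measured steps are a 2.4-fold higher number from compound 1 to compound 3 (0.37 log units; beyond the scatter), a 10-fold higher number from compound 1 to compound 2 (1.01 log units; beyond the scatter) and a 4.3-fold lower number from compound 2 to compound 3 (0.63 log units; beyond the scatter); every one of them exchanges the group on the ring that carries methoxy, chloro or trifluoromethyl, and leaves the rest of the shared core untouched.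

Compound 4 `COc1ccc(Nc2nc3ccccc3nc2S(=O)(=O)c2ccc(F)cc2)cc1` differs from compound 1 by fluoro in place of hydrogen on an aromatic carbon, cut one bond further out phenyl to 4-fluorophenyl, on an aromatic carbon of a six-membered aromatic ring of carbon only, para to a large group. Among the compounds with values here, no measured step varies this ring, so the known steps give no direct guide to its effect. The expected step in this assay is therefore none beyond the scatter, with a 1.0-fold lower number from compound 1 to compound 4 (0.00 log units; within the scatter) as the estimated step. For compound 4 the estimate is 1500 nM, with a range from 600 nM to 3800 nM.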

Compound 4, half-maximal inhibitory concentration: 4330 nM
For compound 4 the middle estimate is 2.9-fold (0.46 log units) below the measured one, and the stated range ends below it.
By their numbers in this assay, from the lowest: compound 1; then compounds 3 and 4 (each within the scatter of the next); then compound 2.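

In this assay the ring that goes from phenyl to 4-fluorophenyl proves responsive, with a 2.9-fold higher number from compound 1 to compound 4 (0.46 log units; beyond the scatter) as the result of a single fluoro in place of hydrogen, on an aromatic carbon para to a large group. Going by these compounds alone, the earlier compounds varied only the ring carrying methoxy, chloro or trifluoromethyl, so this is the first sign that the other ring also affects this read-out, and in this one case the change runs toward weaker inhibition. No measured information bears on the cause of this step.

Going by these compounds, whether the step belongs to fluoro itself or to any replacement of hydrogen here remains open, and a methyl, a hydroxyl or an amine at the same place would separate the two. Also open, on these data alone, is whether the step holds with chloro or trifluoromethyl in place of methoxy on the other ring.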